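A few compounds are considered here, and "the series" means these few. Any claim that something is new, unique, unknown or untested is made for them only; others in the source may bear on it.

Compound 1 `C[C@]1(CN2CCc3nc(-c4ccccc4)ncc3C2)Cn2cc([N+](=O)[O-])nc2O1`, compound 2 `C[C@]1(CN2CCc3oc(-c4ccc(F)cc4)nc3C2)Cn2cc([N+](=O)[O-])nc2O1` and compound 3 `C[C@]1(CN2CCc3nc(-c4ccc(C#N)cc4)ccc3C2)Cn2cc([N+](=O)[O-])nc2O1` share a nitro-bearing core and differ in the aryl-substituted bicyclic amine attached to it. In an ADME assay on Vero cells (Chlorocebus sabaeus) for cytotoxicity, read by MTT assay, with a stated time of 72 h (on this read-out lower numbers stand for higher toxicity in this test and higher numbers for lower toxicity in this test), compound 1 gives "not determined" (no result reported) and compound 3 gives "not determined" (no result reported), so compound 3 stands without a number to place it among the others. For compound 2 the result in this assay is a limit, > 32 ug/mL. Within the data shown here, the only evidence on cytotoxicity is the limit of > 32 ug/mL in this assay, at which 1 of the 3 values shown sits. Compound 4 `C[C@]1(CN2CCc3nc(-c4cc(F)c(F)c(F)c4)ccc3C2)Cn2cc([N+](=O)[O-])nc2O1` carries 3,4,5-trifluorophenyl in place of 4-cyanophenyl on an aromatic carbon. With no number for compound 3, the step to compound 4 in this assay cannot be sized; no shift beyond the scatter is assumed. For compound 4 in this assay a value of 40 ug/mL is expected, within 16 ug/mL to 100 ug/mL, most likely again reported only as a limit.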

Compound 4, half-maximal cytotoxic concentration: > 32 ug/mL
Compound 4: no number, only a limit; the forecaster's own chance of this, stated with the estimate: 70%; the middle value is on the limit's open side.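

Among these compounds, no step from compound 3 to compound 4 can be read in this assay, as compound 3 has no single number there. Compound 4 gives > 32 ug/mL, which is a limit and not a number. The compounds shown leave open where the actual half-maximal cytotoxic concentrations lie and whether changing the aryl group shifts them.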